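Benzylation of the core ring nitrogen in compound 3

This account rests on a few compounds, and the source may have more. Where it says the series, first, only, none or still open, it means among the compounds named here.

In a physicochemical assay for solubility, read by HPLC, measured as kinetic solubility, with a stated time of 24 h, at pH 6.5 (on this read-out lower numbers stand for lower solubility and higher numbers for higher solubility), compound 3 `CCNCc1cc(Cl)cc(Nc2nc3cc(F)c(F)cc3[nH]2)c1O` gives 12000 nM, the lowest of the three numbers measured; the gaps to compound 1 and to compound 2 are both beyond the scatter. Compound 1 `CCNCc1cc(C)cc(Nc2nc3ccccc3n2Cc2ccc(C(F)(F)F)cc2)c1O` gives 35000 nM in this assay, and compound 2 `Cc1cc(CNC(C)(C)C)c(O)c(Nc2nc3ccccc3n2Cc2ccc(C(F)(F)F)cc2)c1` gives 50000 nM. For the measured compounds named here, the one measured step, a 1.4-fold higher number from compound 1 to compound 2 (0.15 log units; within the scatter), concerns the amine substituent and says nothing about the ring nitrogen.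

Compound 4 `CCNCc1cc(Cl)cc(Nc2nc3cc(F)c(F)cc3n2Cc2ccc(C(F)(F)F)cc2)c1O` differs from compound 3 by 4-(trifluoromethyl)benzyl in place of hydrogen on an aromatic nitrogen. Going by the values given here, no measured pair isolates this change: compound 1 and compound 2 carry the same benzyl group yet also differ from compound 3 in the halogen pattern of the core and in the substituent on the phenol ring, so their higher numbers cannot be read as the effect of the benzyl group alone. A 4-(trifluoromethyl)benzyl group is added, and on this basis a decrease in this assay is expected for compound 4, estimated as a 2.4-fold lower number from compound 3 to compound 4 (0.38 log units; beyond the scatter). Compound 4 is expected to give 5000 nM, with a range of 1000 nM to 25000 nM.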

Compound 4, solubility: < 5000 nM
Compound 4 gave a limit, no number; the forecaster's own chance of this, stated with the estimate: 10%; the middle value lies on the limit itself.
By their numbers in this assay, from the lowest: compound 3; then compounds 1 and 2 (each within the scatter of the next). At a limit, below all of these: compound 4.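

With 4-(trifluoromethyl)benzyl in place of hydrogen on the aromatic nitrogen, the step in this assay is an at least 2.4-fold lower number from compound 3 to compound 4 (0.38 log units; beyond the scatter). Compound 4 gives < 5000 nM, which is a limit of the assay and not a number: the limit of < 5000 nM in this assay, at which 1 of the 4 values shown sits. For the compounds shown here, this is the first pair that isolates a change at this nitrogen; until now, the benzyl group appeared only alongside differences in the halogen pattern of the core and the substituent on the phenol ring.

From the compounds shown here alone, it remains open whether the step belongs to the benzyl group as a whole or to its trifluoromethyl, and a plain benzyl, a methyl or a benzyl carrying a carboxylic acid would bear on this. Also open, going by these compounds, is how large the step would be on the core of compound 1.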